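The source may hold more compounds than are shown below. What is called first, only, known or untested is meant among the compounds shown, and "the series" means these compounds.

Of the compounds shown here, two with a shared core have been measured in an assay for displacement of a labelled ligand from Adrenergic receptor alpha-1 (Homo sapiens); a lower number here means a stronger inhibitor, a higher number a weaker inhibitor. Compound 1 `Cn1c(=O)cnn(CCCCN2CCN(c3ccccc3OCCCF)CC2)c1=O` carries a 3-fluoropropoxy group on an aromatic carbon, and in this assay compound 1 gives 280 nM. Compound 2 `Cn1c(=O)cnn(CCCCN2CCN(c3ccccc3C#N)CC2)c1=O` carries a cyano group in that place instead, and in this assay compound 2 gives 7.3 nM. Among the measured compounds shown here, the single step between them, a 38-fold lower number from compound 1 to compound 2 (1.58 log units; beyond the scatter), shows that exchanging the group on this aromatic ring can move the number a great deal. Of the two numbers, compound 2 has the lower one, and its nearest neighbour is compound 1.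

Compound 3 `Cn1c(=O)cnn(CCCCN2CCN(c3ncccc3F)CC2)c1=O` has not yet been measured. It differs from compound 2 in one place: 3-fluoropyridin-2-yl in place of 2-cyanophenyl on an amine nitrogen in a ring. For the measured compounds named here, no measured step covers this exchange; the step from compound 1 to compound 2 only shows how strongly a change on this aromatic ring can act. In compound 2 the cyano group goes with 7.3 nM, and with that group gone a higher number is expected. Compound 3 is expected to give 40 nM in this assay, within 10 nM to 160 nM. Going by the values given here, the expected step, a 5.5-fold higher number from compound 2 to compound 3 (0.74 log units; beyond the scatter), is a moderate rise, and it is uncertain because a 38-fold lower number from compound 1 to compound 2 (1.58 log units; beyond the scatter) is the only guide.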

Compound 3, inhibition constant: > 10000 nM
Compound 3: a limit, no number; the forecaster's own chance of this, stated with the estimate: 5%; middle value at least 250-fold (2.39 log units) away from the limit.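

Compound 3 gives a limit, not a number: the limit of > 10000 nM in this assay, at which 1 of the 3 values shown sits. Exchanging 2-cyanophenyl for 3-fluoropyridin-2-yl on the amine nitrogen in the ring gives an at least 1300-fold higher number from compound 2 to compound 3 (3.13 log units; beyond the scatter), which is the largest step shown so far in this assay. The earlier step changed only the group carried on a carbon-only aromatic ring, whereas this one replaces the whole aromatic group, so it shows that a swap of similar size, with 7 heavy atoms entering where 8 leave, can take compound 2, the lowest number shown, to the limit reached by compound 3.

This single step changes the ring atoms and the attached group together, so the compounds shown cannot tell whether the rise goes with the ring nitrogen of the pyridine, the fluorine, or the loss of the nitrile. As far as these compounds go, a plain phenyl group, 2-fluorophenyl or 3-cyanopyridin-2-yl in this same place would separate these changes, and how any of them reads in this assay remains open.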